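From Compound 1 to Compound 4: One Ring Swap

This account rests on a few compounds, and the source may have more. Where it says the series, first, only, none or still open, it means among the compounds named here.

Compound 1, `COc1ccc(C)cc1N1C(=O)CSC1c1cccc(C(=O)NCCCCc2ccccc2)c1`, gives 29% in a functional assay on 143B cells (Homo sapiens) for inhibition, read by CCK-8 assay, with a stated time of 72 h, tested at 1 uM; on this read-out higher numbers stand for more inhibition at the one concentration tested (going by the name of the read-out) and lower numbers for less inhibition.
Compound 2, `CCN1C(=O)CSC1c1cccc(C(=O)NCCCCc2ccccc2)c1`, gives 40% in this assay.
Compound 3, `COc1ccccc1N1C(=O)CSC1C(=O)NCCCCc1ccccc1`, gives 4% in this assay.

Compound 1 stands second highest of the three numbers; compound 2 lies above it and compound 3 below it, both beyond the scatter. Compound 4, `COc1c(F)cccc1N1C(=O)CSC1c1cccc(C(=O)NCCCCc2ccccc2)c1`, differs from compound 1 in a single place: 3-fluoro-2-methoxyphenyl in place of 2-methoxy-5-methylphenyl on an amide-type nitrogen in a ring. For the measured compounds named here, the only measured single step, a number 11 percentage points higher from compound 1 to compound 2 (beyond the scatter), exchanges the whole ring for an ethyl and so does not bear on one ring giving way to another; compound 3 differs from compound 1 in more than one place. Going by the values given here, no measured step therefore speaks to this change, and no step beyond the scatter is expected in this assay. Compound 4 is estimated at 29%, between 12% and 48%, which means an expected step of no change at the digits printed from compound 1 to compound 4 (within the scatter).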

Compound 4, a percentage reported as inhibition, at one concentration (the size of the read-out at that concentration, not a potency): 5%
Compound 4: the middle estimate sits 24 percentage points above what was measured; measured number outside the range, below it.
By their numbers in this assay, from the lowest: compounds 3 and 4 (each within the scatter of the next); then compound 1; then compound 2.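

In this assay, the exchange of 2-methoxy-5-methylphenyl for 3-fluoro-2-methoxyphenyl on the amide-type nitrogen gives a number 24 percentage points lower from compound 1 to compound 4 (beyond the scatter) even though the two rings have the same heavy-atom count, so this position distinguishes one substituted phenyl ring from another. Replacing ethyl with the fluorinated ring gives a number 35 percentage points lower from compound 2 to compound 4 (beyond the scatter) and is the larger of the two steps. No evidence on the origin of these steps is available.

From the compounds shown here alone, whether the fall follows the added fluorine or the lost methyl remains open. So does how a chloro group on the ring or a propyl chain on this nitrogen would fare.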